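Tetrabromo core series: aryl versus methyl on the carbinol carbon

The source may report more compounds than this note shows. Statements on the series, on what has been measured and on what is new or still open speak of the compounds shown alone.

Three compounds sharing one core have numbers in a functional assay on CCRF-CEM cells (Homo sapiens) for antiproliferative activity, read by MTT assay, with a stated time of 24 h, tested at 12.5 uM; on this read-out higher numbers stand for a weaker effect at the one concentration tested and lower numbers for a stronger effect. Compound 1 `OC(CCn1nc2c(Br)c(Br)c(Br)c(Br)c2n1)c1cccc(Br)c1` gives 102% in this assay, compound 2 `OC(CCn1nc2c(Br)c(Br)c(Br)c(Br)c2n1)c1ccc(Br)cc1` gives 101%, and compound 3 `CC(O)CCn1nc2c(Br)c(Br)c(Br)c(Br)c2n1` gives 106%. Compound 3 stands highest of the three numbers, but every gap is within the scatter: a number 4 percentage points higher from compound 1 to compound 3 (within the scatter) and a number 5 percentage points higher from compound 2 to compound 3 (within the scatter), and between the two aryl compounds a number 1 percentage points lower from compound 1 to compound 2 (within the scatter). None of the three shows an effect at the single concentration.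

Compound 4 `OC(CCn1nc2c(Br)c(Br)c(Br)c(Br)c2n1)c1ccc(Cl)cc1` differs from compound 3 as follows: 4-chlorophenyl in place of methyl on a saturated chain carbon bound to an oxygen on a saturated carbon and a saturated chain carbon. Going by the values given here, the steps that bear on this are the reverse of the two methyl-for-aryl steps already seen, a number 4 percentage points higher from compound 1 to compound 3 (within the scatter) and a number 5 percentage points higher from compound 2 to compound 3 (within the scatter), both inside the scatter; the halogen swap itself has no measured counterpart. A step of no size beyond the scatter is therefore expected, a number 4 percentage points lower from compound 3 to compound 4 (within the scatter). Compound 4 is expected to give 102% in this assay, within 93% to 111%.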

Compound 4, a percentage reported as activity, at one concentration (the size of the read-out at that concentration, not a potency): 105%
Compound 4: the middle estimate sits 3 percentage points below what was measured; the range from low to high includes it.
By their numbers in this assay, from the lowest: compounds 2, 1, 4 and 3 (each within the scatter of the next).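

In this assay the exchange of methyl for 4-chlorophenyl on this saturated chain carbon bound to an oxygen (a number 1 percentage points lower from compound 3 to compound 4 (within the scatter)) is a third methyl-aryl step inside the scatter, now with a chlorine-bearing ring. The halogen exchange, new to the series, also stays inside the scatter, with chloro in place of bromo on an aromatic carbon (a number 4 percentage points higher from compound 2 to compound 4 (within the scatter)), as does the exchange of 3-bromophenyl for 4-chlorophenyl (a number 3 percentage points higher from compound 1 to compound 4 (within the scatter)), so neither the halogen nor its ring position separates these compounds at the single concentration. No supporting data are available to explain this flat result.

On these data alone, it remains open whether this assay would move beyond the scatter with an amine or a carboxylic acid on this carbon, or with a longer chain to the shared core. As far as these compounds go, whether these four compounds separate at any other concentration also remains open.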